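The source may hold more compounds than are shown below. What is called first, only, known or untested is meant among the compounds shown, and "the series" means these compounds.

Compound 2 `O=S(=O)(Nc1ccc2oc(-c3ccccc3)nc2c1)c1ccc(Cl)c(Cl)c1` is one of two compounds examined in an assay on isolated protein for inhibition of malate dehydrogenase, mitochondrial (Sus scrofa), with stated times of 45 min and 30 min; on this read-out lower numbers stand for stronger inhibition and higher numbers for weaker inhibition. In this assay compound 2 gives > 63000 nM, which is a limit of the assay rather than a number. Compound 1 `O=S(=O)(Nc1ccc2oc(-c3ccccc3)nc2c1)c1ccc(Cl)c(C(F)(F)F)c1` carries a trifluoromethyl group where compound 2 carries chloro. In this assay compound 1 likewise gives only a limit, > 63000 nM. Going by the values given here, the single measured step, a step that the two limits leave unreadable from compound 1 to compound 2, cannot be read because both values sit at the limit of > 63000 nM in this assay, at which 2 of the 2 values shown sit. Compound 3 `O=[N+]([O-])c1cc(S(=O)(=O)Nc2ccc3oc(-c4ccccc4)nc3c2)ccc1Cl` differs from compound 2 in one place: nitro in place of chloro on an aromatic carbon. No measured step bears directly on this change, and the one step shown has no readable size. Compound 3 is therefore expected to remain at or near the limit as well, with an expected step of a number no higher from compound 2 to compound 3 (the limit leaves the size open). The estimated value for compound 3 in this assay is 63000 nM, with an expected range from 15000 nM to 250000 nM.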

Compound 3, half-maximal inhibitory concentration: > 63000 nM
Compound 3 gave a limit, no number; the forecaster's own chance of this, stated with the estimate: 75%; the middle value sits exactly at the limit.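

No new step can be read in this assay among compound 1, compound 2 and compound 3, as all three values are the same limit and not numbers: the limit of > 63000 nM in this assay, at which 3 of the 3 values shown sit. The compounds shown leave open how trifluoromethyl, chloro and nitro compare in inhibition.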